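A few compounds are considered here, and "the series" means these few. Any claim that something is new, unique, unknown or untested is made for them only; others in the source may bear on it.

Compound 1, `COc1cc(/C=C/C(C)=O)ccc1OCc1cn(-c2ccc(/N=N/c3ccccc3)cc2)nn1` — in a functional assay on MCF7 cells (Homo sapiens) for antiproliferative activity, read by MTT assay, with a stated time of 48 h (a lower number here means a stronger inhibitor, a higher number a weaker inhibitor), compound 1 gives 75900 nM.
Compound 2, `COc1cc(/C=C/C(C)=O)ccc1OCc1cn(-c2c(Cl)cccc2Cl)nn1` — in this assay compound 2 gives 26600 nM.
Compound 3, `COc1cc(/C=C/C(C)=O)ccc1OCc1cn(-c2ccccc2Cl)nn1` — in this assay compound 3 gives 2190 nM.

All three share the same core and differ only in the aromatic ring attached to the triazole. Compound 1 stands highest of the three numbers, meaning it is the weakest inhibitor measured; compound 2 is nearest to it, and compound 3 is furthest away. Among the compounds with values here, the one step that can be read from a single change is a 12-fold lower number from compound 2 to compound 3 (1.08 log units; beyond the scatter), a large move that concerns a chloro group on the ring, not the group that is changed here.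

Compound 4, `COc1cc(/C=C/C(C)=O)ccc1OCc1cn(-c2ccc(-c3ccccc3)cc2)nn1`, is made from compound 1 by a group of 6 heavy atoms (6 carbon; one six-membered aromatic ring of carbon only) in place of a group of 8 heavy atoms (6 carbon, 2 nitrogen; one six-membered aromatic ring of carbon only), on an aromatic carbon, at the place described as on an aromatic carbon of a six-membered aromatic ring of carbon only, para to a large group. Within the data shown here, no measured step bears directly on this change, so the expectation rests on compound 1 alone, the weakest of the three in this assay. Compound 4 is estimated to give 35000 nM in this assay, within 10000 nM to 120000 nM. The step this estimate means, a 2.2-fold lower number from compound 1 to compound 4 (0.34 log units; beyond the scatter), is expected to be modest and uncertain in direction.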

Compound 4, half-maximal inhibitory concentration: 65400 nM
Compound 4: the middle estimate sits 1.9-fold (0.27 log units) below what was measured; the range from low to high includes it.
By their numbers in this assay, from the lowest: compound 3; then compound 2; then compounds 4 and 1 (each within the scatter of the next).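

In this assay, phenyl in place of the group of 8 heavy atoms gives a 1.2-fold lower number from compound 1 to compound 4 (0.06 log units; within the scatter), so the two compounds cannot be told apart. Within the data shown here, this is the first direct reading at this position, on an aromatic carbon para to a large group: taking away the 2 nitrogen atoms, the double bond outside the aromatic rings and the 2 hydrogen-bond acceptors counted for the leaving group leaves no difference that rises above the scatter. Nothing measured here explains why these two groups match, and no supporting data on the cause are available.

As far as these compounds go, both groups tested at this position end in an unsubstituted six-membered aromatic ring, so it remains open whether the outer ring matters at all, or whether a much smaller group on the same carbon, such as methyl, an amine or a carboxylic acid, would move the number in either direction. From the compounds shown here alone, compound 4 also differs from compound 2 and compound 3 in more than one place, so how its phenyl compares with the chloro groups on those compounds remains open too.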